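The source may hold more compounds than are shown below. What is called first, only, known or untested is meant among the compounds shown, and "the series" means these compounds.

Of the compounds shown here, three have so far been tested in a functional assay on the whole organism (strain albino) for inhibition, with Rattus norvegicus as the target, read by paw edema, with stated times of 30 min and 3 h, at a dose of 5 mg/kg by the oral route; a higher number here means more inhibition at the dose given (going by the name of the read-out), a lower number less inhibition. Compound 1 `CCOC(=O)Cc1nc(N)n(C(=O)c2ccc(Cl)cc2)n1` and compound 2 `CCOC(=O)Cc1nc(N)n(C(=O)c2ccc(Br)cc2)n1` share one core and differ only in a single substituent. In this assay compound 1 gives 62.8%, and compound 2 gives 64.1%. The change that separates them is bromo in place of chloro on an aromatic carbon, and it made a step of a number 1.3 percentage points higher from compound 1 to compound 2 (within the scatter), so the two values cannot be told apart by this measurement.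

Compound 3 `CCOC(=O)Cc1n[nH]c(NC(=O)c2ccc(Cl)cc2)n1` is built from the same atoms as compound 1, joined in a different way; the difference between the two cores is not broken down here. In this assay compound 3 gives 58.5%, a value that lies within the usual scatter of both earlier numbers, so the inhibition numbers of the three cannot be placed in an order by this measurement.

Compound 4 `CCOC(=O)Cc1n[nH]c(NC(=O)c2ccc(Br)cc2)n1` has not yet been measured. It differs from compound 3 by bromo in place of chloro on an aromatic carbon, which is the same change that turns compound 1 into compound 2, at the same kind of place on the same kind of ring. For compound 4 the expected step is a number 1.5 percentage points higher from compound 3 to compound 4 (within the scatter), set beside the measured one, because a number 1.3 percentage points higher from compound 1 to compound 2 (within the scatter) stayed within the scatter and the same change is being made here. The estimate for compound 4 in this assay is therefore 60%, with an expected range from 50% to 70%.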

Compound 4, a percentage reported as inhibition, in the whole organism at one dose (the size of the read-out at that dose, not a potency): 58.8%
Compound 4: the middle estimate sits 1.2 percentage points above what was measured; the measured number falls inside the stated range.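

In this assay, going from 4-chlorophenyl to 4-bromophenyl on the second core gave a step of a number 0.3 percentage points higher from compound 3 to compound 4 (within the scatter), so this pair, like the first, cannot be separated by this measurement. Set side by side, the two steps show no difference between the cores that this measurement can detect: the same change on two cores in this assay, a number 1.3 percentage points higher (within the scatter) from compound 1 to compound 2 and a number 0.3 percentage points higher (within the scatter) from compound 3 to compound 4, 1 percentage points apart, within the scatter of two such steps This shows that on these two cores the swap of chloro for bromo left the inhibition reading within its usual scatter, so the small step seen on one core was a fair guide to the step on the other; it does not show that the two halogens are equivalent in general, that a small real difference is absent, or that the same would hold on a third core or at another dose.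

The compounds shown leave open what happens when the halogen on the phenyl ring gives way to a group of another kind, such as a methoxy group or an amine, since only chloro and bromo appear at this place. They also leave open how inhibition would respond on either core if the ethyl ester gave way to a carboxylic acid.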